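The source may hold more compounds than are shown below. What is called first, only, known or untested is meant among the compounds shown, and "the series" means these compounds.

Measured compounds:
compound 1 `O=C(COc1ccccc1)Nc1nc(-c2ccc(Br)cc2)cs1`, 54300 nM in a functional assay on MCF7 cells (Homo sapiens) for cytotoxicity, read by MTT assay, with a stated time of 48 h; on this read-out lower numbers stand for stronger inhibition and higher numbers for weaker inhibition
compound 2 `CC(C)c1ccccc1OCC(=O)Nc1nc(-c2ccc(Br)cc2)cs1`, 42500 nM in this assay
compound 3 `CC(C)c1ccccc1OCC(=O)Nc1nc(-c2ccc(Cl)cc2)cs1`, 18700 nM in this assay

The change from compound 1 to compound 2 is isopropyl in place of hydrogen on an aromatic carbon and gave a 1.3-fold lower number from compound 1 to compound 2 (0.11 log units; within the scatter). The next step gave a 2.3-fold lower number from compound 2 to compound 3 (0.36 log units; beyond the scatter). Compound 4 `CC(C)c1ccc(OCC(=O)Nc2nc(-c3ccc(Cl)cc3)cs2)c(C(C)C)c1` has not yet been measured in this assay; it differs from compound 3 by isopropyl in place of hydrogen on an aromatic carbon. This is the same kind of change as from compound 1 to compound 2, but not the same: in compound 2 the entering isopropyl is ortho to a large group, whereas in compound 4 it is meta to an isopropyl group and para to a large group. The difference between the two cores, compound 1 and compound 3, is not broken down here. Because the earlier step was a 1.3-fold lower number from compound 1 to compound 2 (0.11 log units; within the scatter), a step of similar, small size is expected here, a 1.3-fold lower number from compound 3 to compound 4 (0.13 log units; within the scatter). Compound 4 is therefore estimated at 14000 nM in this assay, expected to fall between 6000 nM and 35000 nM.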

Compound 4, half-maximal inhibitory concentration: 40100 nM
Beside the measured number, compound 4's estimate is 2.9-fold (0.46 log units) below it; the whole stated range lies below it.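

In this assay, isopropyl in place of hydrogen gave a 2.1-fold higher number from compound 3 to compound 4 (0.33 log units; beyond the scatter), and this step does not match the earlier one, so the change did not carry over from one core to the other with the same outcome: the same change on two cores in this assay, a 1.3-fold lower number (0.11 log units; within the scatter) from compound 1 to compound 2 and a 2.1-fold higher number (0.33 log units; beyond the scatter) from compound 3 to compound 4, 2.7-fold (0.44 log units) apart, beyond the scatter of two such steps The two steps also differ in place: in compound 4 the entering isopropyl is meta to an isopropyl group and para to a large group, so this pair cannot separate the role of the core from that of the place. For the compounds shown here, it is only one pair of steps and says nothing about other cores. Going by these compounds, it remains open how a methyl, a longer chain or an amine in that same place would compare with compound 3 and compound 4.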